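Trifluoromethyl replaces ethoxy on a weak antiproliferative compound

The compounds below may be only part of what the source reports. "The series", "measured", "known", "first", "only" and "open" are said of these compounds alone.

Measured in a functional assay on A-375 cells (Homo sapiens) for antiproliferative activity, read by MTT assay, with a stated time of 24 h; on this read-out lower numbers stand for stronger inhibition and higher numbers for weaker inhibition:
Compound 1 `CCc1ccc2nc(C(=O)Nc3c(F)cc(-c4cccc(F)c4)cc3F)c(C)c(O)c2c1`: 8130 nM
Compound 2 `Cc1c(C(=O)Nc2c(F)cc(-c3cccc(F)c3)cc2F)nc2ccc(F)cc2c1O`: 65300 nM
Compound 3 `CCOc1ccc2nc(C(=O)Nc3c(F)cc(-c4cccc(F)c4)cc3F)c(C)c(O)c2c1`: > 100000 nM

These three compounds differ in a single group on the same aromatic carbon of the shared core. Compound 3 stands at the limit of > 100000 nM in this assay, at which 1 of the 3 values shown sits. That figure is a limit, not a number.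

The next compound to be tested is compound 4 `Cc1c(C(=O)Nc2c(F)cc(-c3cccc(F)c3)cc2F)nc2ccc(C(F)(F)F)cc2c1O`, which carries trifluoromethyl in place of ethoxy on that aromatic carbon: trifluoromethyl in place of ethoxy on an aromatic carbon.

Three measured steps involve the same carbon. Fluoro in place of ethyl gave an 8.0-fold higher number from compound 1 to compound 2 (0.90 log units; beyond the scatter), a modest step. Ethoxy in place of ethyl gave an at least 12-fold higher number from compound 1 to compound 3 (1.08 log units; beyond the scatter), a large one. Ethoxy in place of fluoro gave an at least 1.5-fold higher number from compound 2 to compound 3 (0.18 log units; that floor lies within the scatter).

So both groups tried in place of ethyl gave clearly higher numbers, and no group other than ethyl has yet given a low one. Trifluoromethyl is therefore expected to land nearer compound 2, at 65300 nM, than compound 1, at 8130 nM. A small move toward lower numbers is expected, and the result could still reach the limit. The estimated step is an at least 2.2-fold lower number from compound 3 to compound 4 (0.34 log units; beyond the scatter). For compound 4 the estimate is 45000 nM, with an expected range of 15000 nM to 100000 nM.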

Compound 4, half-maximal inhibitory concentration: 12600 nM
Beside the measured number, compound 4's estimate is 3.6-fold (0.55 log units) above it; the whole stated range lies above it.
By their numbers in this assay, from the lowest: compounds 1 and 4 (each within the scatter of the next); then compound 2. At a limit, above all of these: compound 3.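

Until now, each group tried on this aromatic carbon in place of ethyl had given a clearly higher number in this assay, but trifluoromethyl breaks that run, with a 1.5-fold higher number from compound 1 to compound 4 (0.19 log units; within the scatter). A low number here is therefore not tied to ethyl alone, and a fluorine-containing group does not settle the outcome by itself, as swapping fluoro for trifluoromethyl gives a 5.2-fold lower number from compound 2 to compound 4 (0.71 log units; beyond the scatter). Swapping ethoxy for trifluoromethyl gives an at least 7.9-fold lower number from compound 3 to compound 4 (0.89 log units; beyond the scatter), which is only a floor, as compound 3 has a limit and not a number: the limit of > 100000 nM in this assay, at which 1 of the 4 values shown sits.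

The compounds shown leave open whether an amine, a carboxylic acid or a longer chain such as propyl on this carbon could give a number clearly lower than that of compound 1, at 8130 nM. They also do not tell what ethyl and trifluoromethyl have in common that fluoro and ethoxy lack, so the change in activity at this position can be described but not yet explained.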